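The source may hold more compounds than are shown below. What is called first, only, known or untested is meant among the compounds shown, and "the series" means these compounds.

Of the compounds shown here, two with a shared core have been measured in an assay on C6 cells for antagonist activity at prostaglandin E2 receptor EP2 subtype (Homo sapiens), read by TR-FRET, with stated times of 10 min and 40 min, tested at 1 uM; a higher number here means a weaker inhibitor, a lower number a stronger inhibitor. Compound 1, `COc1cc(CCC(=O)NCCn2c(C)cc3ccccc32)cc(OC)c1OC`, gives 214 nM in this assay. Compound 2, `Cc1cc2ccccc2n1CCNC(=O)/C=C/c1ccc(OCCCN(C)C)cc1`, gives 74.6 nM in this assay. Compound 2 has the lowest of the two numbers; the nearest to it is compound 1, whose number is higher by a margin beyond the scatter, so on the numbers shown compound 2 is the stronger inhibitor of the pair. The two structures differ in more than one place, so nothing more is said about what separates them.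

Compound 3, `Cc1cc2ccccc2n1CCNC(=O)/C=C/c1ccc(OCCO)cc1`, has not yet been measured in this assay. It differs from compound 2 in a single place: hydroxy in place of (dimethylamino)methyl on a saturated chain carbon, two bonds along the chain from an oxygen on an aromatic ring. Among the measured compounds shown here, there is no measured step of this kind among the two compounds to lean on, so the expectation rests on compound 2 alone. A moderate weakening, giving a higher number than compound 2, is expected for compound 3, with the step of a 2.7-fold higher number from compound 2 to compound 3 (0.43 log units; beyond the scatter) counted as the estimate. Compound 3 is therefore expected to show about 200 nM in this assay, within a range from 70 nM to 600 nM.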

Compound 3, antagonist equilibrium constant in the prostaglandin E2 receptor EP2 subtype assay: 13.6 nM
Beside the measured number, compound 3's estimate is 15-fold (1.17 log units) above it; measured number below the stated range.
By their numbers in the prostaglandin E2 receptor EP2 subtype assay, from the lowest: compound 3; then compound 2; then compound 1.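

In the prostaglandin E2 receptor EP2 subtype assay, hydroxy in place of (dimethylamino)methyl on a saturated chain carbon, two bonds along the chain from an oxygen on an aromatic ring, gives a 5.5-fold lower number from compound 2 to compound 3 (0.74 log units; beyond the scatter). Among the compounds shown here, this is the first step read at this place, and it shows that the number responds strongly to what the chain carries and that the dimethylamino group is not needed for the stronger inhibition seen here. The same change has a cost in a physicochemical assay for solubility, read by nephelometry, in phosphate buffer, at pH 7.4 (on this read-out higher numbers stand for higher solubility and lower numbers for lower solubility), where compound 2 gives 306000 nM and compound 3 gives 68000 nM, so the compound carrying hydroxy is the less soluble of the pair: the measured solubility of compound 2, 306000 nM, and of compound 3, 68000 nM, a 4.5-fold lower number (0.65 log units; beyond the scatter)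

One step cannot separate the effect of the hydroxy that enters from that of the (dimethylamino)methyl that leaves, so the reason for the lower number in the prostaglandin E2 receptor EP2 subtype assay remains unknown. The compounds shown also leave open whether a methoxy, a carboxylic acid or a longer chain such as 3-hydroxypropoxy at the same place would keep this inhibition, and whether any of these would recover the solubility of compound 2.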